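This account rests on a few compounds, and the source may have more. Where it says the series, first, only, none or still open, it means among the compounds named here.

Measured compounds:
- Compound 1 `CCOC(=O)C1=C(C)NC(=O)N(CCC(=O)NNS(=O)(=O)c2ccccc2)C1c1cccc([N+](=O)[O-])c1`: 50%
- Compound 2 `CCOC(=O)C/C(C)=N\NC(=O)CCN1C(=O)NC(C)=C(C(=O)OCC)C1c1cccc([N+](=O)[O-])c1`: "not active" (no number reported)
- Compound 3 `CCOC(=O)C1=C(C)NC(=O)N(CCC(=O)n2nc(C)cc2C)C1c1cccc([N+](=O)[O-])c1`: "not active" (no number reported)

Three compounds sharing one core were tested in an assay on cells for inhibition of Voltage-dependent L-type calcium channel subunit alpha-1C (Rattus norvegicus), read by patch clamp, tested at 10 uM; on this read-out higher numbers stand for more inhibition at the one concentration tested (going by the name of the read-out) and lower numbers for less inhibition. Compound 1 reaches 50%. Compound 2 is reported as "not active" (no number reported) with no number given. Compound 3, carrying the 3,5-dimethyl-1H-pyrazol-1-yl group on the carbonyl carbon of its side chain, likewise comes back as "not active" (no number reported), so it stands without a number, alongside compound 2, and only compound 1 among the measured set has a figure in this assay.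

Compound 4 `CCOC(=O)C1=C(C)NC(=O)N(CCC(=O)NNC(=S)Nc2ccccc2)C1c1cccc([N+](=O)[O-])c1` has not yet been measured. It differs from compound 3 by a group of 11 heavy atoms (7 carbon, 3 nitrogen, 1 sulfur; one six-membered aromatic ring of carbon only) in place of a group of 7 heavy atoms (5 carbon, 2 nitrogen; one five-membered aromatic ring with 2 hetero atoms), on a carbonyl carbon. Among the compounds with values here, no comparable step between measured compounds exists, so the size of the step can only be guessed. The entering group brings the hydrazide part closer to that of compound 1, which gives 50%, and so a rise beyond the scatter relative to the inactive compound 3 is expected, though it may again be reported without a number. The estimate for compound 4 is 35%, in the range from 10% to 60%.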

Compound 4, a percentage reported as inhibition, at one concentration (the size of the read-out at that concentration, not a potency): "not active" (no number reported)
Compound 4: no number reported; the estimate stays without a comparison.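

In this assay compound 4, like compound 3, comes back without a number, so no step can be read between them. Nothing available here bears on this result. The compounds shown leave open how much inhibition, if any, compound 3 and compound 4 actually give.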